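The compounds below may be only part of what the source reports. "The series", "measured", "known", "first", "only" and "open" are said of these compounds alone.

Measured compounds:
Compound 1, `O=C(O)Cc1sc(C(c2ccc(F)cc2)c2ccc(F)cc2)nc1-c1ccnc(N2CCCC2)c1`: 80%
Compound 2, `O=C(O)Cc1sc(C(c2ccccc2)c2ccc(Cl)cc2)nc1-c1ccc(Cl)cc1`: 80%
Compound 3, `O=C(O)Cc1sc(C(c2ccccc2)c2ccc(Cl)cc2)nc1-c1ccc(F)cc1`: 80%

In an in vitro functional assay on HEK285-7 cells for antagonist activity at prostaglandin D2 receptor 2 (Homo sapiens), read by BRET and beta-arrestin recruitment (a higher number here means a larger maximal response, a lower number a smaller maximal response), compound 2 gives 80%, and it stands level with compounds 1 and 3: in this assay compound 1 gives 80% and compound 3 gives 80%; none of these three is separated from another beyond the scatter. Among the compounds with values here, the one step measured between compounds that differ in a single place, no change at the digits printed from compound 2 to compound 3 (within the scatter), shows no movement beyond the scatter for fluoro in place of chloro on an aromatic carbon.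

Compound 4, `CCC(c1ccccc1)c1nc(-c2ccc(Cl)cc2)c(CC(=O)O)s1`, differs from compound 2 by ethyl in place of 4-chlorophenyl on a saturated chain carbon bound to two aromatic carbons. Within the data shown here, no measured step exchanges an aromatic ring for a chain at this position, so the measured data bear on the change only in a general way: the single known step was flat, and all three measured compounds sit at the same level. Compound 4 is therefore expected to stay near that level, with a somewhat widened range because the change is of a kind not yet tested. The expected step, a number 4 percentage points lower from compound 2 to compound 4 (within the scatter), is judged not to exceed the scatter. Compound 4 is estimated at 76%, with a range from 55% to 95%.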

Compound 4, largest response reached (reported as efficacy), in percent of the reference or control that the assay uses: 50%
Beside the measured number, compound 4's estimate is 26 percentage points above it, outside the stated range (below it).
By their numbers in this assay, from the lowest: compound 4; then compounds 1, 2 and 3 (each within the scatter of the next).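

In this assay, within the data shown here, the exchange gives a number 30 percentage points lower from compound 2 to compound 4 (beyond the scatter) for ethyl in place of 4-chlorophenyl on a saturated chain carbon bound to two aromatic carbons, the first step here to go beyond the scatter. This position therefore responds to a change in a way that the flat exchange of fluoro for chloro on an aromatic carbon did not show, and the read-out depends on what is carried there. Nothing given here explains this fall.

The compounds shown leave open whether the step follows the loss of the ring or the loss of the chlorine, which an unsubstituted phenyl, a cyclohexyl ring or a longer chain such as butyl at this place could separate. The step also rests on a single pair of compounds, so it cannot yet be said to hold on other substituted versions of the shared core.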